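The compounds below may be only part of what the source reports. "The series", "measured", "known", "first", "only" and "open" are said of these compounds alone.

Measured compounds:
compound 1, `Nc1cc(N)c2nc(-c3ccccc3)c(NCc3ccc(Cl)c(Cl)c3)nc2c1`, 18600 nM
compound 2, `COc1ccc(CNc2nc3cc(N)cc(N)c3nc2-c2ccccc2)cc1OC`, 21900 nM
compound 3, `CCOC(=O)[C@H](CCC(=O)O)NC(=O)c1ccc(Sc2nc3cc(N)cc(N)c3nc2-c2ccccc2)cc1`, 17800 nM

In a functional assay on SK-OV-3 cells (Homo sapiens) for inhibition, read by sulforhodamine B assay, with a stated time of 48 h (a higher number here means a weaker inhibitor of growth, a lower number a stronger inhibitor of growth), compound 2 gives the highest of the three numbers, yet its gaps to compound 1 and to compound 3 both fall within the scatter, so the three values cannot be ranked. Compound 4, `COc1cc(CNc2nc3cc(N)cc(N)c3nc2-c2ccccc2)cc(OC)c1OC`, differs from compound 2 by methoxy in place of hydrogen on an aromatic carbon. Within the data shown here, the only measured step that touches this part of the molecule is a 1.2-fold higher number from compound 1 to compound 2 (0.07 log units; within the scatter), which exchanged both substituents on that ring without a change beyond the scatter. On that basis the added methoxy group is expected to leave the value where it is, a step of a 1.0-fold higher number from compound 2 to compound 4 (0.00 log units; within the scatter). Compound 4 is therefore estimated at 22000 nM, with a range from 11000 nM to 44000 nM.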

Compound 4, concentration for 50% growth inhibition: 5370 nM
Beside the measured number, compound 4's estimate is 4.1-fold (0.61 log units) above it; the whole stated range lies above it.
By their numbers in this assay, from the lowest: compound 4; then compounds 3, 1 and 2 (each within the scatter of the next).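

In this assay, adding methoxy on an aromatic carbon ortho to a methoxy group gave a 4.1-fold lower number from compound 2 to compound 4 (0.61 log units; beyond the scatter) and is the only step shown that lies beyond the scatter. The earlier exchange of both ring substituents gave only a 1.2-fold higher number from compound 1 to compound 2 (0.07 log units; within the scatter) and so did not show that the number could respond to a change on this ring. No evidence available here accounts for the step.

The compounds shown leave open whether this step is particular to methoxy. An ethoxy group or a hydroxyl group at the same place could test this.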